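The compounds below may be only part of what the source reports. "The series", "measured", "known", "first", "only" and "open" are said of these compounds alone.

Compound 1 `COc1ccc(-c2nc3cc(C(F)(F)F)ccc3[nH]2)c(OC)c1`: > 100000 nM in an ADME assay on MDBK cells (Bos taurus) for cytotoxicity, read by MTT assay, with a stated time of 96 h (on this read-out higher numbers stand for lower toxicity in this test and lower numbers for higher toxicity in this test), a limit of the assay.
Compound 2 `COc1ccc(-c2nc3cc(C(F)(F)F)ccc3[nH]2)cc1`: > 100000 nM in this assay, likewise a limit of the assay.
Compound 3 `COc1ccc(-c2nc3cc(C(F)(F)F)ccc3[nH]2)c([N+](=O)[O-])c1`: 55000 nM in this assay.

Compound 3 holds the only number in the set; the other two values are limits, as shown by the limit of > 100000 nM in this assay, at which 2 of the 3 values shown sit. The step that the two limits leave unreadable from compound 1 to compound 2 cannot be read. The steps of an at least 1.8-fold lower number from compound 1 to compound 3 (0.25 log units; that floor lies within the scatter) and an at least 1.8-fold lower number from compound 2 to compound 3 (0.25 log units; that floor lies within the scatter) are floors only and lie within the scatter. Compound 4 `COc1ccc(-c2nc3cc(C(F)(F)F)ccc3[nH]2)c(N)c1` is not yet measured in this assay. It differs from compound 3 by amino in place of nitro on an aromatic carbon. Within the data shown here, no measured step exchanges nitro for amino, so the two floors leading to compound 3 are the nearest guides, and they set no size. No step beyond the scatter is therefore expected in this assay. The step expected from this change, a 1.5-fold higher number from compound 3 to compound 4 (0.16 log units; within the scatter), is small. Compound 4 is estimated at 80000 nM, with a range from 30000 nM to 200000 nM, and a fair chance that only a limit is reported.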

Compound 4, half-maximal cytotoxic concentration: 4000 nM
Estimate against measurement, compound 4: 20-fold (1.30 log units) above; measured number outside the range, below it.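

Among these compounds, at this position, ortho to a large group, the exchange of nitro for amino gives the first step that reads beyond the scatter in this assay: a 14-fold lower number from compound 3 to compound 4 (1.14 log units; beyond the scatter). Amino also separates from hydrogen and methoxy at the same place, with an at least 25-fold lower number from compound 2 to compound 4 (1.39 log units; beyond the scatter) and an at least 25-fold lower number from compound 1 to compound 4 (1.39 log units; beyond the scatter), so this position responds strongly to the group it carries, and amino gives the lowest number of the four. Those two steps are floors only, as they start from limits of the assay: the limit of > 100000 nM in this assay, at which 2 of the 4 values shown sit.

The compounds shown leave open whether this step belongs to the free amino group, which a methylamino, dimethylamino or acetamido group at the same place would test. They also leave open whether a hydroxyl group there would give a similar step.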